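Replacing cyclobutyl with 2,2,2-trifluoroethyl: clearance notes

This account rests on a few compounds, and the source may have more. Where it says the series, first, only, none or still open, it means among the compounds named here.

Measured in an ADME assay on cells (Hepatocyte, Rattus norvegicus) for pharmacokinetics, read by LC-MS, with a stated time of 90 min, tested at 1 uM; a lower number here means slower removal, a higher number faster removal of the compound:
- compound 1 `COC(=O)N(CCO)c1c(N)nc(-c2nn(Cc3ccccc3F)c3ncccc23)nc1N`: 61.7 mL/min/kg
- compound 2 `COC(=O)Nc1c(N)nc(-c2nn(Cc3ccccc3F)c3ncccc23)nc1N`: 1.67 mL/min/kg
- compound 3 `Nc1nc(-c2nn(Cc3ccccc3F)c3ncccc23)nc(N)c1NC(=O)OC1CCC1`: 23.3 mL/min/kg

Of the three, compound 3 stands second highest at 23.3 mL/min/kg. The highest value lies close to it, with a 2.6-fold lower number from compound 1 to compound 3 (0.42 log units; beyond the scatter).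

Next is compound 4 `Nc1nc(-c2nn(Cc3ccccc3F)c3ncccc23)nc(N)c1NC(=O)OCC(F)(F)F`, with this change: 2,2,2-trifluoroethyl in place of cyclobutyl on an oxygen next to a carbonyl group. In words, this is 2,2,2-trifluoroethyl in place of cyclobutyl on an oxygen next to a carbonyl group.

The most relevant measured step sits at this same place and is large: a 14-fold higher number from compound 2 to compound 3 (1.14 log units; beyond the scatter). The other large step, a 37-fold lower number from compound 1 to compound 2 (1.57 log units; beyond the scatter), lies on an amide-type nitrogen and bears on this change only weakly. Among the measured compounds shown here, no measured compound carries 2,2,2-trifluoroethyl, so the size of the step remains uncertain. The entering group has no ring, as with the methyl of compound 2 at 1.67 mL/min/kg, so a partial return toward that value is expected. The expected step is a 3.3-fold lower number from compound 3 to compound 4 (0.52 log units; beyond the scatter). The estimate for compound 4 is 7 mL/min/kg, with an expected range of 2 mL/min/kg to 25 mL/min/kg.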

Compound 4, clearance: 35 mL/min/kg
Compound 4: the middle estimate sits 5.0-fold (0.70 log units) below what was measured; the whole stated range lies below it.
By their numbers in this assay, from the lowest: compound 2; then compounds 3, 4 and 1 (each within the scatter of the next, the first and the last beyond it).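

In this assay, 2,2,2-trifluoroethyl and cyclobutyl on this oxygen cannot be told apart (a 1.5-fold higher number from compound 3 to compound 4 (0.18 log units; within the scatter)), so the absence of a ring does not by itself bring the number back toward that of compound 2. The methyl group stays apart from 2,2,2-trifluoroethyl (a 21-fold higher number from compound 2 to compound 4 (1.32 log units; beyond the scatter)), and among the three groups shown on this oxygen only methyl gives a low number, while compound 4 also lies within the scatter of the differently substituted compound 1 (a 1.8-fold lower number from compound 1 to compound 4 (0.25 log units; within the scatter)). No available evidence bears on the reason for this separation.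

Going by these compounds, whether an ethyl group, the closest step up from methyl, stays near compound 2 or joins compound 4 remains open. Also open, on these data alone, is how a 2-methoxyethyl group on this oxygen would behave.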